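Notes on cytotoxicity limits, step to compound 4

The source may hold more compounds than are shown below. What is called first, only, known or untested is meant among the compounds shown, and "the series" means these compounds.

Measured so far in an ADME assay on RD cells (Homo sapiens) for cytotoxicity; a lower number here means that less compound is tolerated, a higher number that more compound is tolerated:
compound 1 `O=C(N/N=C1\C(=O)Nc2ccccc21)Nc1ccccc1` gives > 25000 nM, a limit of the assay.
compound 2 `CN(C)C(=S)N/N=C1/C(=O)Nc2ccccc21` gives > 25000 nM, a limit of the assay.
compound 3 `O=C1Nc2ccccc2/C1=N/NC(=S)Nc1ccc(-n2cccn2)cc1` gives > 25000 nM, a limit of the assay.

Every value recorded so far in this assay is a limit rather than a number, and all three sit at the same point (the limit of > 25000 nM in this assay, at which 3 of the 3 values shown sit). For the measured compounds named here, compound 3 therefore stands with compound 1 and compound 2 at that limit; nothing among the numbers sets it apart, and no step between measured compounds is available, since none of the pairs differs in only one place.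

Compound 4 `O=C1Nc2ccccc2/C1=N/NC(=S)Nc1ccccc1` has not yet been tested in this assay. It differs from compound 3 in one place:
hydrogen in place of 1H-pyrazol-1-yl on an aromatic carbon

Going by the values given here, with no measured step to lean on, the expectation rests on the three limits alone. Compound 4 is expected to show no step beyond the scatter, a step that the limit leaves unreadable from compound 3 to compound 4, because all values recorded so far sit at the limit of > 25000 nM in this assay, at which 3 of the 3 values shown sit. Compound 4 is estimated at 30000 nM, within 15000 nM to 60000 nM, with the likeliest outcome again a limit rather than a number.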

Compound 4, half-maximal cytotoxic concentration: > 25000 nM
Compound 4: no number, only a limit; the forecaster's own chance of this, stated with the estimate: 80%; the middle value does not contradict the limit.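

In this assay compound 4 gives > 25000 nM as a limit of the assay. No step can be read between compound 3 and compound 4, because both stand at the same limit: the limit of > 25000 nM in this assay, at which 4 of the 4 values shown sit. The compounds shown leave open whether hydrogen in place of 1H-pyrazol-1-yl changes the tolerated concentration, and where any of the four compounds would give an actual number.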